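Amide variation on the chloro-phenyl oxadiazole azetidine series

The compounds below may be only part of what the source reports. "The series", "measured", "known", "first", "only" and "open" are said of these compounds alone.

In an assay on HEK293 cells for positive allosteric modulation of metabotropic glutamate receptor 5 (Homo sapiens), read by FLIPR (on this read-out lower numbers stand for an effect already at smaller amounts and higher numbers for an effect only at larger amounts of compound), compound 1 `CC1CCC(C(=O)N2CC(c3nc(-c4cccc(Cl)c4)no3)C2)CC1` gives 1500 nM, compound 2 `O=C([C@@H]1CC2CCC1C2)N1CC(c2nc(-c3cccc(Cl)c3)no2)C1` gives 98 nM and compound 3 `O=C(N1CCCCC1)N1CC(c2nc(-c3cccc(Cl)c3)no2)C1` gives 370 nM, the second highest number of the three; the closest is a 3.8-fold higher number from compound 2 to compound 3 (0.58 log units; beyond the scatter), the farthest a 4.1-fold lower number from compound 1 to compound 3 (0.61 log units; beyond the scatter). Compound 4 `CC1CCN(C(=O)N2CC(c3nc(-c4cccc(Cl)c4)no3)C2)C1` differs from compound 3 by 3-methylpyrrolidin-1-yl in place of piperidin-1-yl on a carbonyl carbon. For the measured compounds named here, no measured step swaps one ring-nitrogen amide for another of different ring size; the steps seen, a 15-fold lower number from compound 1 to compound 2 (1.18 log units; beyond the scatter), a 4.1-fold lower number from compound 1 to compound 3 (0.61 log units; beyond the scatter) and a 3.8-fold higher number from compound 2 to compound 3 (0.58 log units; beyond the scatter), all concern carbon-only rings against the piperidinyl amide and are modest to large. With the same atoms rearranged, no step beyond the scatter is expected, a 1.2-fold lower number from compound 3 to compound 4 (0.06 log units; within the scatter). Compound 4 is therefore estimated at 320 nM, within 120 nM to 850 nM.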

Compound 4, half-maximal effective concentration: > 10000 nM
Compound 4: a limit, no number; the forecaster's own chance of this, stated with the estimate: 5%; middle value at least 31-fold (1.49 log units) from the limit.
By their numbers in this assay, from the lowest: compound 2; then compound 3; then compound 1. At a limit, above all of these: compound 4.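

Compound 4 gives > 10000 nM in this assay, a limit and not a number. On the carbonyl carbon, 3-methylpyrrolidin-1-yl in place of piperidin-1-yl gives an at least 27-fold higher number from compound 3 to compound 4 (1.43 log units; beyond the scatter), so this position separates two groups with the same atoms, a difference the carbon-only rings could not show. The other amides give an at least 100-fold higher number from compound 2 to compound 4 (2.00 log units; beyond the scatter) and an at least 6.6-fold higher number from compound 1 to compound 4 (0.82 log units; beyond the scatter), which places compound 4 beyond all three earlier compounds.

The shown compounds cannot separate the smaller ring from the methyl group. Pyrrolidin-1-yl without the methyl would divide the two.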